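Pyridin-2-yl in place of 3-methoxyphenyl: compound 4

A few compounds are considered here, and "the series" means these few. Any claim that something is new, unique, unknown or untested is made for them only; others in the source may bear on it.

In a physicochemical assay for lipophilicity, at pH 7.4 (on this read-out lower numbers stand for lower lipophilicity and higher numbers for higher lipophilicity), compound 1 `CNC(=O)c1cc(C(=O)N[C@H]2[C@@H]3COC[C@@H]32)cc2c1OC[C@H]2c1cccc(OC)c1` gives 3.2, the middle of three numbers. Compound 2 `CNC(=O)c1cc(C(=O)NC2CC2)cc2c1OC[C@H]2c1cccc(OC)c1` stands higher at 3.8, and compound 3 `CNC(=O)c1cc(C(=O)N[C@H]2[C@@H]3COC[C@@H]32)cc2c1OC[C@@]2(CO)c1ccccc1` stands lower at 2.4.

The next compound to be measured is compound 4 `CNC(=O)c1cc(C(=O)N[C@H]2[C@@H]3COC[C@@H]32)cc2c1OC[C@H]2c1ccccn1`. Its change from compound 1 is pyridin-2-yl in place of 3-methoxyphenyl on a saturated ring carbon, two ring bonds from the ring oxygen.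

Going by the values given here, the only measured step is a number 0.60 log units higher from compound 1 to compound 2 (beyond the scatter). This modest step is on an amide-type nitrogen, not on the saturated ring carbon, so it bears only indirectly. It does show that the number in this assay can move beyond the scatter with a single change. Among the compounds with values here, no measured step isolates a change at the saturated ring carbon, so the size below is a judgement from the structural change itself. A downward step, larger than the one measured, is expected. The estimated step is a number 0.90 log units lower from compound 1 to compound 4 (beyond the scatter). For compound 4 the estimated value is 2.3, with an expected range of 1.8 to 2.7.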

Compound 4, distribution coefficient: 1.6
Compound 4: middle estimate off by 0.70 log units, on the high side; measured number below the stated range.
By their numbers in this assay, from the lowest: compound 4; then compound 3; then compound 1; then compound 2.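

Going by these compounds alone, the saturated ring carbon, two ring bonds from the ring oxygen, proves highly sensitive in this assay: pyridin-2-yl in place of 3-methoxyphenyl gives the largest single-change shift so far (a number 1.60 log units lower from compound 1 to compound 4 (beyond the scatter)). Within the data shown here, this step runs opposite in direction to the only earlier step, on an amide-type nitrogen, and is larger (a number 0.60 log units higher from compound 1 to compound 2 (beyond the scatter)). No measurement on hand accounts for the size of the new step.

The change alters the aromatic ring and removes the methoxy group at once, and the compounds shown do not separate these two parts. On these data alone, how pyridin-3-yl or pyridin-4-yl would compare at this carbon stays open, as does whether the step carries over with the amide-type nitrogen group of compound 2 in place.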